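Fluoro in Place of Methoxymethoxy: Cytotoxicity Still Expected Unreadable

The compounds below may be only part of what the source reports. "The series", "measured", "known", "first", "only" and "open" are said of these compounds alone.

Measured so far:
- compound 1 `COCOc1cccc(C(=O)/C=C/c2ccc3c(c2)B(O)OC3)c1`: > 10 ug/mL
- compound 2 `O=C(/C=C/c1ccc2c(c1)B(O)OC2)c1ccc([N+](=O)[O-])cc1`: > 10 ug/mL
- compound 3 `O=C(/C=C/c1ccc2c(c1)B(O)OC2)c1ccc(-c2ccccc2)cc1`: > 10 ug/mL

In an ADME assay on L929 cells (Mus musculus) for cytotoxicity, read by resazurin assay, with a stated time of 72 h (a lower number here means a stronger inhibitor, a higher number a weaker inhibitor), compound 1 gives > 10 ug/mL; this is a limit of the assay, not a number. The same holds for compound 2, whose value > 10 ug/mL is a limit. Compound 3 likewise gives > 10 ug/mL, again a limit. For the measured compounds named here, compound 1 therefore stands nowhere on a scale of numbers: all three values sit at the limit (the limit of > 10 ug/mL in this assay, at which 3 of the 3 values shown sit), so no compound can be placed before or behind another.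

Compound 4 `O=C(/C=C/c1ccc2c(c1)B(O)OC2)c1cccc(F)c1` differs from compound 1 in one place: fluoro in place of methoxymethoxy on an aromatic carbon. Going by the values given here, the only measured step between two compounds that differ in one place, a step that the two limits leave unreadable from compound 2 to compound 3, is unreadable, because both of its values are limits. It concerns a different position and a different pair of groups, so it carries no size over to the step from compound 1 to compound 4.

Given that every measured value sits at the limit (the limit of > 10 ug/mL in this assay, at which 3 of the 3 values shown sit), compound 4 is expected to give a limit as well, and the estimated step that the limit leaves unreadable from compound 1 to compound 4 is expected to show no readable size. The estimate for compound 4 is 15 ug/mL, with a range from 7 ug/mL to 40 ug/mL.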

Compound 4, half-maximal inhibitory concentration: > 10 ug/mL
Compound 4 was reported as a limit (the forecaster's own chance of this, stated with the estimate: 80%); the middle value lies beyond the limit too.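

No size can be read for the step between compound 1 and compound 4, since both values are limits, not numbers: the limit of > 10 ug/mL in this assay, at which 4 of the 4 values shown sit. The compounds shown leave open whether any of them differs from another in this assay, and at what concentration each would reach half-maximal inhibition.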